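The compounds below may be only part of what the source reports. "The series", "measured", "known", "first", "only" and "open" are said of these compounds alone.

The study covers three compounds on a shared core. Compound 1 `Oc1cccc(-c2cc(-c3cccnc3)nc(-c3cccc(Cl)c3)c2)c1` was examined, and in a functional assay on T47D cells (Homo sapiens) for cytotoxicity, read by CCK-8 assay and cell counting, with a stated time of 2 days (on this read-out lower numbers stand for stronger inhibition and higher numbers for weaker inhibition), compound 1 returns "not determined" (no result reported). For the measured compounds named here, compound 2 `Oc1ccc(-c2cc(-c3ccc(Cl)cc3)nc(-c3cccnc3)c2)cc1` is the only compound with a number: in this assay compound 2 gives 29300 nM, and with compound 1 lacking a value it stands alone, so it can be ranked against nothing. Compound 3 `Oc1ccc(-c2cc(-c3ccc(Cl)cc3)nc(-c3cccs3)c2)cc1` has not yet been measured. It differs from compound 2 in one place: thiophen-2-yl in place of pyridin-3-yl on an aromatic carbon. Going by the values given here, no step between measured compounds is available to show what such an exchange does here, and the single value of compound 2 gives no direction. Compound 3 is therefore expected to stay close to compound 2, with a step from compound 2 to compound 3 of a 1.0-fold higher number from compound 2 to compound 3 (0.01 log units; within the scatter) that is not expected to exceed the scatter. The estimate for compound 3 in this assay is 30000 nM, within 10000 nM to 90000 nM.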

Compound 3, half-maximal inhibitory concentration: 6450 nM
For compound 3 the middle estimate is 4.7-fold (0.67 log units) above the measured one; measured number outside the range, below it.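

In this assay, the exchange of pyridin-3-yl for thiophen-2-yl on the aromatic carbon next to the ring nitrogen gives a 4.5-fold lower number from compound 2 to compound 3 (0.66 log units; beyond the scatter). This shows that the position is not indifferent to the ring it carries: with the 4-chlorophenyl and 4-hydroxyphenyl groups unchanged, a five-membered aromatic ring with sulfur in place of a six-membered aromatic ring with nitrogen moves the read-out towards stronger inhibition. Nothing available explains what in this exchange produces the step.

This single pair does not separate the change in ring size from the change of hetero atom. Going by these compounds, how a plain phenyl, a thiophen-3-yl or a pyridine ring bearing an amine would behave at this position remains open, as does whether the step would recur with the substituents placed as in compound 1.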